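A few compounds are considered here, and "the series" means these few. Any claim that something is new, unique, unknown or untested is made for them only; others in the source may bear on it.

Measured so far:
Compound 1 `COc1ccccc1-n1cc(COc2c(/C=C\C(=O)O)ccc(OC)c2CC=C(C)C)nn1`: 32600 nM
Compound 2 `COc1ccc(/C=C\C(=O)O)c(OCc2cn(-c3ccccc3C#N)nn2)c1CC=C(C)C`: 10300 nM

Of these two numbers in a functional assay on A-431 cells (Homo sapiens) for cytotoxicity, read by MTT assay, with a stated time of 24 h (a higher number here means a weaker inhibitor, a lower number a stronger inhibitor), compound 1 gives the highest; its nearest neighbour is compound 2, reached by a 3.2-fold lower number from compound 1 to compound 2 (0.50 log units; beyond the scatter), a modest step. Compound 3 `COc1ccc(/C=C\C(=O)O)c(OCc2cn(-c3nc4ccccc4s3)nn2)c1CC=C(C)C` is not yet measured. It differs from compound 1 in one place: 1,3-benzothiazol-2-yl in place of 2-methoxyphenyl on an aromatic nitrogen. Within the data shown here, the only measured step that bears on this change sits in the same part of the molecule, where cyano took the place of methoxy on an aromatic carbon and gave a 3.2-fold lower number from compound 1 to compound 2 (0.50 log units; beyond the scatter). Swapping the whole 2-methoxyphenyl for 1,3-benzothiazol-2-yl is a broader change than that, so the direction is uncertain, though the one step seen so far points towards a lower number. Compound 3 is therefore expected to give about 16000 nM in this assay, within 5000 nM to 50000 nM, which would amount to an expected 2.0-fold lower number from compound 1 to compound 3 (0.31 log units; beyond the scatter).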

Compound 3, half-maximal inhibitory concentration: 20800 nM
Compound 3: middle estimate off by 1.3-fold (0.11 log units), on the low side, within the range that was stated.
By their numbers in this assay, from the lowest: compound 2; then compounds 3 and 1 (each within the scatter of the next).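

In this assay, exchanging the single ring of 2-methoxyphenyl for the two fused rings of 1,3-benzothiazol-2-yl on the aromatic nitrogen gives a 1.6-fold lower number from compound 1 to compound 3 (0.20 log units; within the scatter), so this position takes the larger ring system with no change that can be told from the scatter. Set against the 2-cyanophenyl group, the same 1,3-benzothiazol-2-yl group gives a 2.0-fold higher number from compound 2 to compound 3 (0.31 log units; beyond the scatter), which leaves compound 2 as the strongest of the three, and the 2-cyanophenyl group as the only one here to stand clear of the others. No measurement shown here explains these differences.

From the compounds shown here alone, all three compounds carry an aromatic group on this nitrogen, so what a plain alkyl chain would do there remains open. Also open, going by these compounds, is how a phenyl ring bearing an amine in place of the nitrile would compare.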